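Extending the ethyl chain to propyl in permeability

This account rests on a few compounds, and the source may have more. Where it says the series, first, only, none or still open, it means among the compounds named here.

In an ADME assay on MDCKII-LE cells (Canis lupus familiaris) for permeability (on this read-out higher numbers stand for higher permeability and lower numbers for lower permeability), the measured compounds are these:
compound 1 `Cc1cnc(NC(=O)c2cc(Oc3cnc(C(=O)N(C)C)cn3)c3cn(C)nc3c2)cn1` gives 20.8 10^-6 cm/s
compound 2 `Cc1cnc(NC(=O)c2cc(Oc3ccc(S(C)(=O)=O)cc3)c3cn(C)nc3c2)cn1` gives 20.4 10^-6 cm/s
compound 3 `CCn1cc2c(Oc3ccc(S(C)(=O)=O)cc3)cc(C(=O)Nc3cnc(C)cn3)cc2n1` gives 13.4 10^-6 cm/s

Compound 3 lies within the scatter of both compound 1 and compound 2. Compound 4 `CCCn1cc2c(Oc3ccc(S(C)(=O)=O)cc3)cc(C(=O)Nc3cnc(C)cn3)cc2n1` departs from compound 3 by methyl in place of hydrogen on a saturated chain carbon, two bonds along the chain from an aromatic nitrogen with methyl in place of hydrogen on a saturated chain carbon, two bonds along the chain from an aromatic nitrogen, so that ethyl becomes propyl. Going by the values given here, the one related measured step is a 1.5-fold lower number from compound 2 to compound 3 (0.18 log units; within the scatter) and it places methyl on a saturated chain carbon bound to an aromatic nitrogen. Among the compounds with values here, with that step as the only guide, no change beyond the scatter is expected in this assay here. The expected step is a 1.1-fold lower number from compound 3 to compound 4 (0.05 log units; within the scatter) by this estimate. Compound 4 is expected at 12 10^-6 cm/s within an estimated range of 7 10^-6 cm/s to 20 10^-6 cm/s for now.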

Compound 4, apparent permeability: 14.2 10^-6 cm/s
Beside the measured number, compound 4's estimate is 1.2-fold (0.07 log units) below it; the range from low to high includes it.
By their numbers in this assay, from the lowest: compounds 3, 4, 2 and 1 (each within the scatter of the next).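

In this assay the change from ethyl to propyl gives a 1.1-fold higher number from compound 3 to compound 4 (0.03 log units; within the scatter) and the wider change from methyl to propyl gives a 1.4-fold lower number from compound 2 to compound 4 (0.16 log units; within the scatter) so at this place methyl, ethyl and propyl chains all lie within the scatter of one another. The earlier compounds had shown this only as far as ethyl. No supporting evidence bears on this result.

On these data alone, it remains open whether a longer chain such as butyl would also stay within the scatter. The same question stands for a chain ending in an amine or a carboxylic acid.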